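From a Five-Membered to a Six-Membered Sugar

This account rests on a few compounds, and the source may have more. Where it says the series, first, only, none or still open, it means among the compounds named here.

Compound 1, `C=C1CC[C@@H]2[C@](C)(CC[C@@H](O)[C@]2(C)C(=O)O[C@@H]2O[C@H](CO)[C@@H](O)[C@H](O)[C@H]2O)[C@H]1CCC1=CCOC1=O`: 24100 nM
Compound 2, `C=C1CC[C@@H]2[C@](C)(CCC[C@]2(C)C(=O)O[C@@H]2O[C@@H](CO)[C@H](O)[C@H]2O)[C@H]1CCC1=CCOC1=O`: > 500000 nM

In a functional assay on BV-2 cells (Mus musculus) for inhibition, read by Griess assay, with a stated time of 24 h (a lower number here means a stronger inhibitor, a higher number a weaker inhibitor), compound 1 gives 24100 nM. Compound 2 gives > 500000 nM in this assay, which is a limit of the assay and not a number. Where compound 2 stands is therefore known only through (the limit of > 500000 nM in this assay, at which 1 of the 2 values shown sits), and no step between compound 1 and compound 2 is given, so their two values show only that compound 1 has a measured number and compound 2 does not.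

Compound 3, `C=C1CC[C@@H]2[C@](C)(CCC[C@]2(C)C(=O)O[C@@H]2O[C@H](CO)[C@@H](O)[C@H](O)[C@H]2O)[C@H]1CCC1=CCOC1=O`, is not yet measured. It differs from compound 2 in one place: 3,4,5-trihydroxy-6-(hydroxymethyl)oxan-2-yl in place of 3,4-dihydroxy-5-(hydroxymethyl)oxolan-2-yl on an oxygen next to a carbonyl group. Compound 3 shares this six-membered sugar with compound 1, which has a measured number in this assay, while compound 2 with the five-membered sugar sits at the limit. Compound 3 is therefore expected to move to a lower number than compound 2, a step estimated as an at least 6.2-fold lower number from compound 2 to compound 3 (0.79 log units; beyond the scatter), beyond the usual scatter. Compound 3 is estimated at 80000 nM in this assay, within the range 20000 nM to 400000 nM.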

Compound 3, half-maximal inhibitory concentration: 65800 nM
For compound 3 the middle estimate is 1.2-fold (0.08 log units) above the measured one; the range from low to high includes it.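

In this assay the two changes that separate compound 1 from compound 2 can now be read one at a time, which their own values did not allow. On an oxygen next to a carbonyl group, 3,4,5-trihydroxy-6-(hydroxymethyl)oxan-2-yl in place of 3,4-dihydroxy-5-(hydroxymethyl)oxolan-2-yl gives an at least 7.5-fold lower number from compound 2 to compound 3 (0.88 log units; beyond the scatter) and so accounts for a measurable number with the rest of the structure unchanged, though the size of this step is only a bound, as the value of compound 2 is a limit of the assay and not a number: the limit of > 500000 nM in this assay, at which 1 of the 3 values shown sits. The second change, hydrogen in place of hydroxy on a saturated ring carbon, gives a 2.7-fold higher number from compound 1 to compound 3 (0.44 log units; beyond the scatter) and shows a modest part for that hydroxy group with the six-membered sugar in place.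

The compounds shown leave open whether the step between the sugars follows from the ring size or from the added hydroxy group, and whether the hydroxy group on the saturated ring carbon would count in the same way with the five-membered sugar. They also leave open how a free carboxylic acid at the sugar's place, or an amine or a methoxy group at the place of that hydroxy group, would read.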